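The source may hold more compounds than are shown below. What is called first, only, known or untested is meant among the compounds shown, and "the series" means these compounds.

Working notes on the series. The two measured compounds share one core: compound 1 `COc1ccc(-c2cc(/C=C/C(=O)c3ccc(OC)c(OC)c3)[nH]n2)cc1` and compound 2 `COc1ccc(-c2cc(/C=C/C(=O)c3cc(OC)c(OC)c(OC)c3)[nH]n2)cc1OC`. In a functional assay on NCI-H522 cells (Homo sapiens) for inhibition, read by sulforhodamine B assay, with a stated time of 48 h (on this read-out higher numbers stand for weaker inhibition of growth and lower numbers for stronger inhibition of growth), compound 1 gives 410 nM, and compound 2 gives 1330 nM. On the numbers shown, compound 2 stands highest of the two in this assay, with compound 1 the nearest, and the gap between them lies beyond the scatter. Compound 3 `COc1cc(C(=O)/C=C/c2cc(-c3cc(OC)c(OC)c(OC)c3)n[nH]2)cc(OC)c1OC` is not yet measured in this assay. It differs from compound 2 by a methoxy in place of hydrogen on an aromatic carbon. For the measured compounds named here, no step between measured compounds shows how this exact change behaves, so the expected step is small in either direction and may well fall within the scatter. The number for compound 3 is expected to be 1500 nM, with a range from 500 nM to 4500 nM, which means an expected step of a 1.1-fold higher number from compound 2 to compound 3 (0.05 log units; within the scatter).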

Compound 3, concentration for 50% growth inhibition: 520 nM
Compound 3: the middle estimate sits 2.9-fold (0.46 log units) above what was measured; low and high end bracket the measured number.
By their numbers in this assay, from the lowest: compounds 1 and 3 (each within the scatter of the next); then compound 2.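

In this assay, methoxy in place of hydrogen on an aromatic carbon gives a 2.6-fold lower number from compound 2 to compound 3 (0.41 log units; beyond the scatter) and counts as a modest step, in the direction of stronger inhibition of growth. For the compounds shown here, this is the first single-place step, and it shows that this position, ortho to a methoxy group and meta to a large group, responds to the change. No measurement at hand accounts for the step.

As far as these compounds go, whether an amine, a hydroxyl or a longer alkoxy chain at this position would move the number in the same direction remains open. A single step also leaves open whether the same methoxy change would behave alike on the core of compound 1.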